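Working notes on a small acyl-substituted series

The compounds below may be only part of what the source reports. "The series", "measured", "known", "first", "only" and "open" are said of these compounds alone.

Compound 1 `CS/C(=N\C(=O)c1ccno1)NC(=O)c1ccno1` gives in a functional assay on HT-29 cells (Homo sapiens) for cytotoxicity, read by MTT assay, with a stated time of 72 h; a higher number here means a weaker inhibitor of growth, a lower number a stronger inhibitor of growth > 100000 nM, which is a limit of the assay and not a number.
Compound 2 `O=C(/N=C(/NC(=O)c1ccno1)[Se]Cc1ccccc1)c1ccno1` gives in this assay > 100000 nM, again a limit of the assay.
Compound 3 `O=C(/N=C(/NC(=O)c1cccs1)[Se]Cc1ccccc1)c1cccs1` gives in this assay > 100000 nM, also a limit of the assay.

Going by the values given here, the one counted change among the measured compounds runs from compound 2 to compound 1: a group of 2 heavy atoms (1 carbon, 1 sulfur; no ring) in place of a group of 8 heavy atoms (7 carbon, 1 selenium; one six-membered aromatic ring of carbon only), on a carbon with a double bond to nitrogen. Its step, a step that the two limits leave unreadable from compound 2 to compound 1, cannot be read in size, because both ends sit at the limit of > 100000 nM in this assay, at which 3 of the 3 values shown sit. The difference between the core of compound 3 and the core of compound 2 is not broken down here.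

Compound 4 `CS/C(=N\C(=O)c1cccs1)NC(=O)c1cccs1` has not yet been measured. It differs from compound 3 by a group of 2 heavy atoms (1 carbon, 1 sulfur; no ring) in place of a group of 8 heavy atoms (7 carbon, 1 selenium; one six-membered aromatic ring of carbon only), on a carbon with a double bond to nitrogen, the same change as that from compound 2 to compound 1, at a place described in the same words. Since that change left both of its measured ends at a limit, the expectation for compound 4 is that it too will not be resolved: the step that the limit leaves unreadable from compound 3 to compound 4 is expected to be unreadable in the same way. The value estimated for compound 4 in this assay is 200000 nM, with an expected range from 100000 nM to 1000000 nM, resting on compound 3 showing > 100000 nM and on the limit at which all three measured compounds sit, (the limit of > 100000 nM in this assay, at which 3 of the 3 values shown sit).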

Compound 4, concentration for total growth inhibition: > 100000 nM
Compound 4: only a limit was reported; the forecaster's own chance of this, stated with the estimate: 90%; the middle value is on the limit's open side.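

In this assay compound 4 gives > 100000 nM, which is a limit of the assay and not a number. Going by these compounds alone, the change from compound 3 to compound 4 therefore yields no new readable step, as both of its ends are limits. The compounds shown leave open how these four compounds differ in growth inhibition, and whether any change to them would give a readable value: the limit of > 100000 nM in this assay, at which 4 of the 4 values shown sit.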